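The source may hold more compounds than are shown below. What is called first, only, known or untested is meant among the compounds shown, and "the series" means these compounds.

Measured so far in a functional assay on HeLa cells (Homo sapiens) for antiproliferative activity, read by MTT assay, with a stated time of 72 h; a lower number here means a stronger inhibitor, a higher number a weaker inhibitor:

compound 1, `CCOC(=O)c1cc(=O)c2cc(CSC(=S)N(C(C)C)C(C)C)ccc2o1`, gives > 25000 nM.
compound 2, `O=c1c(SC(=S)N2CCCC2)coc2ccc(Cl)cc12`, gives 16300 nM.
compound 3, `O=c1c(CSC(=S)N2CCN(c3ccccc3)CC2)coc2ccccc12`, gives 7100 nM.

For compound 1 the value is a limit of this assay rather than a number (the limit of > 25000 nM in this assay, at which 1 of the 3 values shown sits). Among the two compounds with real numbers, compound 2 stands at the higher end: compound 2 gives 16300 nM, whereas compound 3 gives 7100 nM, a gap that lies beyond the usual scatter of repeated measurements. All three share a related core, but they are not joined by single-point changes, so no measured step can be read off among them.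

Among the measured compounds shown here, compound 4, `O=c1c(SC(=S)N2CCCCC2)coc2ccc(Cl)cc12`, is the first such single-point partner of compound 2. The change is piperidin-1-yl in place of pyrrolidin-1-yl on a thiocarbonyl carbon. The ring on the thiocarbonyl carbon simply grows by one member while keeping its single nitrogen and lacking any hydrogen-bond donor or acceptor. For the measured compounds named here, with no measured step to lean on, the expectation is a change in this assay no larger than the scatter, in no firm direction. The step from compound 2 to compound 4 is therefore estimated as a 1.3-fold lower number from compound 2 to compound 4 (0.10 log units; within the scatter). Compound 4 is expected to give about 13000 nM, within a range from 5000 nM to 30000 nM.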

Compound 4, half-maximal inhibitory concentration: 8300 nM
Compound 4: the middle estimate sits 1.6-fold (0.19 log units) above what was measured; measured number inside the range.
By their numbers in this assay, from the lowest: compounds 3, 4 and 2 (each within the scatter of the next, the first and the last beyond it). At a limit, above all of these: compound 1.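

Among the compounds shown here, the swap of piperidin-1-yl in place of pyrrolidin-1-yl on a thiocarbonyl carbon gives the first step that can be read in this set, and in this assay it amounts to a 2.0-fold lower number from compound 2 to compound 4 (0.29 log units; within the scatter). For the compounds shown here, at this place, then, the five-membered and six-membered rings cannot be told apart by this measurement, which the earlier compounds, joined by no single-point change, could not show. Nothing available here accounts for the size of this step, and the one recorded note concerns only the assay limit reached by another compound, so it does not bear on this result.

From the compounds shown here alone, it remains open whether a morpholin-4-yl ring, which carries an oxygen atom in the ring, or an open-chain diethylamino group on the same thiocarbonyl carbon would give a number that can be told apart from those of compound 2 and compound 4. Going by these compounds, it also remains open whether the swap between these two rings would read the same way if the chlorine on the shared core were replaced by a methoxy group.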